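The compounds below may be only part of what the source reports. "The series", "measured", "known", "first", "only" and "open" are said of these compounds alone.

Of the compounds shown here, three have been measured in an assay on membranes from Cortex for displacement of a labelled ligand from Sigma non-opioid intracellular receptor 1 (Cavia porcellus), read by scintillation counting, with a stated time of 120 min; a lower number here means a stronger inhibitor, a higher number a weaker inhibitor. Compound 1 `Fc1ccc(C(SCCNC2CCN(Cc3ccc(Cl)cc3)CC2)c2ccc(F)cc2)cc1` gives 45.5 nM and stands second highest of the three numbers. Compound 2 `[O-][S+](CCNC1CCN(Cc2ccc(F)cc2)CC1)C(c1ccc(F)cc1)c1ccc(F)cc1` gives 26.5 nM, a value that lies within the scatter of compound 1, so the two cannot be ordered. Compound 3 `[O-][S+](CCNC1CCN(CC(O)Cc2ccccc2)CC1)C(c1ccc(F)cc1)c1ccc(F)cc1` gives 351 nM, well beyond the scatter of compound 1 on the weaker side. The only single-point step among these compounds, a 13-fold higher number from compound 2 to compound 3 (1.12 log units; beyond the scatter), shows that changing the group carried by the amine nitrogen in the ring costs a large amount of binding.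

Compound 4 `O=C(c1ccc(F)cc1)N1CCC(NCCSC(c2ccc(F)cc2)c2ccc(F)cc2)CC1` differs from compound 1 by (4-fluorophenyl)carbonyl in place of 4-chlorobenzyl on an amine nitrogen in a ring. For the measured compounds named here, no measured pair shows exactly this exchange, but the step from compound 2 to compound 3 alters the substituent on the same ring amine nitrogen and moved the number a long way upward. The exchange here is of a different kind, so the size is uncertain, yet a weakening step beyond the scatter is the expectation, with a step of a 6.6-fold higher number from compound 1 to compound 4 (0.82 log units; beyond the scatter) in this assay. Compound 4 is therefore expected to give about 300 nM in this assay, somewhere between 80 nM and 1500 nM.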

Compound 4, inhibition constant: 32.1 nM
Compound 4: the middle estimate sits 9.3-fold (0.97 log units) above what was measured; the measured number lies below the stated range.
By their numbers in this assay, from the lowest: compounds 2, 4 and 1 (each within the scatter of the next); then compound 3.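

In this assay, putting (4-fluorophenyl)carbonyl in place of 4-chlorobenzyl on the amine nitrogen in the ring gives a 1.4-fold lower number from compound 1 to compound 4 (0.15 log units; within the scatter), so the two compounds cannot be told apart, although the entering group carries a double bond outside aromatic rings and a hydrogen-bond acceptor that the leaving group lacks. The large rise seen at this nitrogen in a 13-fold higher number from compound 2 to compound 3 (1.12 log units; beyond the scatter) therefore does not hold for every exchange there: compound 3, with its 1-hydroxy-2-phenylethyl group, goes with that rise, whereas compound 4 goes against it. Nothing available explains why this exchange is tolerated.

The compounds shown do not separate the part played by the carbonyl from that of the change from chlorine to fluorine on the aromatic ring, since compound 4 differs from compound 1 in both at once. On these data alone, it also remains open whether a sulfonyl group on this nitrogen, or a longer chain leading to the aromatic ring, would stay within the scatter of compound 1.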